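A few compounds are considered here, and "the series" means these few. Any claim that something is new, unique, unknown or untested is made for them only; others in the source may bear on it.

Measured compounds in an assay on Sf9 cells for inhibition of mitogen-activated protein kinase kinase kinase 14 variant S549D (Homo sapiens), with a stated time of 30 min, in the presence of a further agent that is not named here; on this read-out lower numbers stand for stronger inhibition and higher numbers for weaker inhibition:
compound 1 `C#Cc1ccc2ncn(-c3ccnc(N)n3)c2c1`: 251 nM
compound 2 `C=Cc1cc(C#Cc2ccc3ncn(-c4ccnc(N)n4)c3c2)ccn1`: 20000 nM
compound 3 `C#Cc1cccc(C#Cc2ccc3ncn(-c4ccnc(N)n4)c3c2)n1`: 3160 nM

Compound 3 stands second highest of the three numbers in this assay: its nearest neighbour is compound 2, at a 6.3-fold lower number from compound 2 to compound 3 (0.80 log units; beyond the scatter), and furthest from it is compound 1, at a 13-fold higher number from compound 1 to compound 3 (1.10 log units; beyond the scatter). Compound 4 `C#Cc1ccnc(C#Cc2ccc3ncn(-c4ccnc(N)n4)c3c2)c1` is not yet measured. It differs from compound 3 thus: a group of 8 heavy atoms (7 carbon, 1 nitrogen; one six-membered aromatic ring with 1 hetero atom) in place of a group of 8 heavy atoms (7 carbon, 1 nitrogen; one six-membered aromatic ring with 1 hetero atom), on a triple-bonded carbon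

Going by the values given here, the steps that bear on this are those on the same triple-bonded carbon. Both an 80-fold higher number from compound 1 to compound 2 (1.90 log units; beyond the scatter) and a 13-fold higher number from compound 1 to compound 3 (1.10 log units; beyond the scatter) show that any of these groups in place of the hydrogen of compound 1 raises the number a lot. Among the compounds with values here, the one step most like the present change, a swap of one such group for another, is a 6.3-fold lower number from compound 2 to compound 3 (0.80 log units; beyond the scatter), which was modest. Compound 4 shares the attaching arrangement of compound 3 rather than that of compound 2, so a step no larger than that, in either direction, is expected; the estimate for compound 4 is 5000 nM, in the range 1500 nM to 16000 nM, meaning an expected step of a 1.6-fold higher number from compound 3 to compound 4 (0.20 log units; within the scatter).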

Compound 4, half-maximal inhibitory concentration: 316 nM
Estimate against measurement, compound 4: 16-fold (1.20 log units) above, and the stated range ends above it.
By their numbers in this assay, from the lowest: compounds 1 and 4 (each within the scatter of the next); then compound 3; then compound 2.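

In this assay, two groups with the same atoms and the same counts do not behave alike on this triple-bonded carbon: 4-ethynylpyridin-2-yl gives a 10-fold lower number from compound 3 to compound 4 (1.00 log units; beyond the scatter) and a 63-fold lower number from compound 2 to compound 4 (1.80 log units; beyond the scatter), so how the atoms of the group are joined matters here, not only what they are. Compounds 2 and 3 had suggested that any such group costs heavily against hydrogen, but compound 4 goes against that reading, with a 1.3-fold higher number from compound 1 to compound 4 (0.10 log units; within the scatter), so a group of this size can be carried at this place. Nothing shown explains the gap between these groups.

Open, going by these compounds, is whether a nitrile or an amine in place of the ethynyl of 4-ethynylpyridin-2-yl would keep the number in this range. Equally open, on these data alone, is whether the ring nitrogen is needed, which a phenyl group on the same triple-bonded carbon would test.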